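Estimating cytotoxicity after swapping an alkyne's aryl group

This account rests on a few compounds, and the source may have more. Where it says the series, first, only, none or still open, it means among the compounds named here.

Values in an ADME assay on CHO cells (Cricetulus griseus) for cytotoxicity, read by MTT assay, with a stated time of 24 h (on this read-out lower numbers stand for higher toxicity in this test and higher numbers for lower toxicity in this test), for the measured compounds
Compound 1 (`CC1Cn2c(nc([N+](=O)[O-])c2Br)O1`) gives 9190 nM
Compound 2 (`CC1Cn2c(nc([N+](=O)[O-])c2-c2ccccc2)O1`) gives > 500000 nM as a limit of the assay, not a number
Compound 3 (`Cc1ccc(C#Cc2c([N+](=O)[O-])nc3n2CC(C)O3)cc1`) gives 5470 nM

Compound 3 and compound 1 lie within the scatter of each other, and compound 2 offers only a limit. Compound 4 (`CC1Cn2c(nc([N+](=O)[O-])c2C#CC2CC2)O1`) has cyclopropyl in place of 4-methylphenyl on a triple-bonded carbon. The change counts as cyclopropyl in place of 4-methylphenyl on a triple-bonded carbon and is the one to follow here.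

Among the compounds with values here, only one measured step bears on it, and only loosely. The large step of an at least 54-fold higher number from compound 1 to compound 2 (1.73 log units; beyond the scatter) puts phenyl in place of bromo on an aromatic carbon and ends at the limit of > 500000 nM in this assay, at which 1 of the 3 values shown sits, rather than at a true number. Compound 3 also carries an aromatic ring and still gives 5470 nM in this assay so that large step cannot simply be carried over. A modest rise is therefore expected, and the estimated change is a 2.7-fold higher number from compound 3 to compound 4 (0.44 log units; beyond the scatter) in this assay with real uncertainty. For compound 4 the estimated value is 15000 nM with an expected range from 3000 nM to 80000 nM on this thin evidence.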

Compound 4, half-maximal cytotoxic concentration: 6450 nM
Compound 4: the middle estimate sits 2.3-fold (0.37 log units) above what was measured; low and high end bracket the measured number.
By their numbers in this assay, from the lowest: compounds 3, 4 and 1 (each within the scatter of the next). At a limit, above all of these: compound 2.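

In this assay, changing the group on the triple-bonded carbon makes no readable difference: a 1.2-fold higher number from compound 3 to compound 4 (0.07 log units; within the scatter). Compound 4 also stays level with the bromo compound, a 1.4-fold lower number from compound 1 to compound 4 (0.15 log units; within the scatter), so two different groups on the alkyne, 4-methylphenyl and cyclopropyl, both leave the number where bromo has it. Only compound 2 breaks from this group, with a large step that starts from a limit of the assay rather than a number, an at least 77-fold lower number from compound 2 to compound 4 (1.88 log units; beyond the scatter).

Going by these compounds, the true size of that step therefore stays unknown, as does whether any other directly attached ring would behave like the phenyl of compound 2. On these data alone, it also remains open whether an alkyne carrying an amine, a carboxylic acid or a longer chain would stay level with compounds 3 and 4.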